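Cytotoxicity notes on the shared core, compounds 3 and 4

The compounds below may be only part of what the source reports. "The series", "measured", "known", "first", "only" and "open" are said of these compounds alone.

The series shares the core of compound 1 `N#Cc1ccc(Cn2nc(-c3cc(Cl)c(NC[C@H](O)CO)nc3F)c3ccccc3c2=O)cc1` and is read in an ADME assay on HepG2 2.2.15 cells (Homo sapiens) for cytotoxicity, read by MTT assay, with a stated time of 8 days; on this read-out lower numbers stand for higher toxicity in this test and higher numbers for lower toxicity in this test. Compound 1 gives > 100000 nM, which is a limit of the assay and not a number. Compound 2 `N#Cc1ccc(Cn2nc(-c3cc(Cl)c(NCCO)nc3F)c3ccccc3c2=O)cc1` gives 32100 nM. Compound 3 `Cc1ccc(-c2nn(Cc3ccc(C#N)cc3)c(=O)c3ccccc23)c(F)n1` gives > 100000 nM, again a limit and not a number. Two of the three values therefore sit at the same limit (the limit of > 100000 nM in this assay, at which 2 of the 3 values shown sit), and only compound 2 reports a number.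

Going by the values given here, the one measured step is an at least 3.1-fold lower number from compound 1 to compound 2 (0.49 log units; beyond the scatter); it concerns a saturated chain on the amino group and is the only step on this read-out.

Compound 4 `COCCNc1ccc(-c2nn(Cc3ccc(C#N)cc3)c(=O)c3ccccc23)c(F)n1` is not yet measured. It differs from compound 3 by (2-methoxyethyl)amino in place of methyl on an aromatic carbon. Among the compounds with values here, no measured step shares this change; the step from compound 1 to compound 2 touches the same kind of chain and moved the number beyond the scatter, so a change of roughly that size is possible here, but in which direction is not told by the data. Compound 4 is expected to give 60000 nM, between 20000 nM and 150000 nM, so that the expected step is an at least 1.6-fold lower number from compound 3 to compound 4 (0.22 log units; that floor lies within the scatter).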

Compound 4, half-maximal cytotoxic concentration: > 100000 nM
Compound 4: only a limit was reported; the forecaster's own chance of this, stated with the estimate: 45%; at least 1.6-fold (0.22 log units) between middle value and limit.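

In this assay compound 4 gives > 100000 nM, a limit of the assay and not a number. Compound 3 also stands at a limit, so no step between compound 3 and compound 4 can be read: the limit of > 100000 nM in this assay, at which 3 of the 4 values shown sit.

The compounds shown leave open whether (2-methoxyethyl)amino in place of methyl on an aromatic carbon changes the cytotoxicity read-out at all.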